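The source may report more compounds than this note shows. Statements on the series, on what has been measured and on what is new or still open speak of the compounds shown alone.

Compound 1 `COc1ccc(C(=O)O[C@H]2CC(C)=C[C@H](O)[C@@]3(C)[C@@H](OC(C)=O)C[C@@](O)(C(C)C)[C@H]23)cc1`: 48200 nM. Compound 2 `COc1ccc(C(=O)O[C@H]2CC(C)=C[C@@H](OC(C)=O)[C@@]3(C)[C@@H](OC(C)=O)C[C@@](O)(C(C)C)[C@H]23)cc1`: > 100000 nM, a limit of the assay.

In a functional assay on K562 cells (Homo sapiens) for cytotoxicity, read by MTT assay, with a stated time of 72 h (a higher number here means a weaker inhibitor, a lower number a stronger inhibitor), compound 2 reaches only the assay limit of > 100000 nM, so no exact number is known for it. Compound 1 gives 48200 nM in this assay. Compound 3 `COc1ccc(C(=O)O[C@H]2CC(C)=C[C@@H](O)[C@@]3(C)[C@@H](OC(C)=O)C[C@@](O)(C(C)C)[C@H]23)cc1` is not yet measured; it differs from compound 2 by hydrogen in place of acetyl on an oxygen on a saturated carbon. Among the compounds with values here, no measured step covers this change, so the expectation rests on the two values shown. The step of an at least 1.4-fold lower number from compound 2 to compound 3 (0.15 log units; that floor lies within the scatter) is expected to be small, if anything toward a stronger inhibitor. Compound 3 is estimated at 70000 nM, between 25000 nM and 200000 nM.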

Compound 3, half-maximal inhibitory concentration: 85200 nM
Compound 3: middle estimate off by 1.2-fold (0.09 log units), on the low side; the measured number falls inside the stated range.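

In this assay, hydrogen in place of acetyl on this oxygen gives an at least 1.1-fold lower number from compound 2 to compound 3 (0.06 log units; that floor lies within the scatter). That step has only a floor, because one of its ends is a limit: the limit of > 100000 nM in this assay, at which 1 of the 3 values shown sits. Drawing the stereocentre at this saturated ring carbon the other way gives a 1.8-fold higher number from compound 1 to compound 3 (0.25 log units; within the scatter), so the configuration here shows no change beyond the scatter: the fact that compounds 1 and 3 differ only in the configuration as drawn.

The compounds shown leave open whether a different group at this place, such as a methyl ether or an amine, would move the number beyond the scatter.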